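Isothiazole in place of triazole on the aryl ring

A few compounds are considered here, and "the series" means these few. Any claim that something is new, unique, unknown or untested is made for them only; others in the source may bear on it.

Measured so far:
compound 1 `CCC(C)(C)Cc1c[nH]c(CCc2ccc(-n3ncnn3)cc2)n1` — 205 nM
compound 2 `CCC(C)(C)Cc1c[nH]c(CCc2ccc(-n3ccnn3)cc2)n1` — 390 nM

In an in vitro assay on CHO cells for displacement of a labelled ligand from Bombesin receptor subtype-3 (Homo sapiens), read by scintillation counting, with a stated time of 2 h (a lower number here means a stronger inhibitor, a higher number a weaker inhibitor), compound 1 gives 205 nM and compound 2 gives 390 nM. Within the data shown here, the one step available, a 1.9-fold higher number from compound 1 to compound 2 (0.28 log units; within the scatter), lies within the scatter, so the two values cannot be placed in order: compound 2 stands alongside compound 1 with no separation that the assay can resolve.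

Compound 3 `CCC(C)(C)Cc1c[nH]c(CCc2ccc(-c3ccns3)cc2)n1` is not yet measured. It differs from compound 2 by 1,2-thiazol-5-yl in place of 1H-1,2,3-triazol-1-yl on an aromatic carbon. Among the measured compounds shown here, the only step that bears on this position is a 1.9-fold higher number from compound 1 to compound 2 (0.28 log units; within the scatter), which swapped one five-membered aromatic ring for another at the same site without moving the number beyond the scatter. For the measured compounds named here, that step is the sole guide; the entering ring replaces a nitrogen-rich ring with one carrying sulfur, for which there is no measured precedent in this set.

On that basis compound 3 is expected to stay close to compound 2, with the estimated step of a 1.0-fold higher number from compound 2 to compound 3 (0.01 log units; within the scatter) not beyond the scatter. The estimate for compound 3 in this assay is 400 nM, with a range from 150 nM to 1100 nM.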

Compound 3, half-maximal inhibitory concentration: 11 nM
For compound 3 the middle estimate is 36-fold (1.56 log units) above the measured one; measured number outside the range, below it.
By their numbers in this assay, from the lowest: compound 3; then compounds 1 and 2 (each within the scatter of the next).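

In this assay this position, on an aromatic carbon para to a large group, proves able to carry a large change: 1,2-thiazol-5-yl gives a 35-fold lower number from compound 2 to compound 3 (1.55 log units; beyond the scatter) when it replaces 1H-1,2,3-triazol-1-yl and a 19-fold lower number from compound 1 to compound 3 (1.27 log units; beyond the scatter) when it replaces 2H-tetrazol-2-yl. The earlier exchange of one five-membered aromatic ring for another, a 1.9-fold higher number from compound 1 to compound 2 (0.28 log units; within the scatter), stayed within the scatter, so a large step here does not follow from any such exchange and appears only with the ring that carries sulfur and has fewer hetero atoms. Nothing available ties the large step to either of those differences or to any other cause.

The compounds shown do not separate the sulfur atom, the number of ring nitrogens and the attachment through a ring carbon, so a thiophene or a 1,3-thiazole at the same place would bear directly on which of these goes with the lower number. Also open, as far as these compounds go, is how this position responds to something other than a five-membered aromatic ring, such as an amine or a carboxylic acid, and whether the step holds with a different chain on the shared core.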